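The source may report more compounds than this note shows. Statements on the series, on what has been measured and on what is new or still open speak of the compounds shown alone.

Measured so far in an assay on isolated protein for inhibition of leukotriene B4 receptor 1 (Homo sapiens), tested at 10 uM; a lower number here means less inhibition, a higher number more inhibition at the concentration tested (going by the name of the read-out):
compound 1, `CCc1cc(C(C)=O)c(O)cc1OCCCCC(C)(C)C#N`: 79%
compound 2, `CCc1cc(C(C)=O)c(O)cc1OCCCCCC(C)(C)C(=O)O`: 104%

Among the compounds with values here, compound 2 stands highest of the two numbers; its only neighbour is compound 1, and the single step known so far, a number 25 percentage points higher from compound 1 to compound 2 (beyond the scatter), separates them. That step exchanges the nitrile end of the chain for the acid end and is the whole of the measured evidence in this series.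

Compound 3, `CCc1cc(C(C)=O)c(O)cc1OCCCC(C)(C)c1nnn[nH]1`, is not yet measured. It differs from compound 2 by 1-(1H-tetrazol-5-yl)-1-methylethyl in place of 3-carboxy-3-methylbutyl on a saturated chain carbon, three bonds along the chain from an oxygen on an aromatic ring. Within the data shown here, no measured step covers this exchange: the step from compound 1 to compound 2 replaced a nitrile by a carboxylic acid, whereas here the carboxylic acid itself gives way to a tetrazole on a shorter chain. The modest rise seen in a number 25 percentage points higher from compound 1 to compound 2 (beyond the scatter) therefore gives no direction for the present change, and compound 2 already reads near the top of the percentage scale, so little room remains upward. For compound 3 the expected step is a number 9 percentage points lower from compound 2 to compound 3 (within the scatter), not beyond the scatter. Compound 3 is estimated at 95%, within 75% to 110%.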

Compound 3, a percentage reported as inhibition, at one concentration (the size of the read-out at that concentration, not a potency): 100%
Beside the measured number, compound 3's estimate is 5 percentage points below it, within the range that was stated.
By their numbers in this assay, from the lowest: compound 1; then compounds 3 and 2 (each within the scatter of the next).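

In this assay, 1-(1H-tetrazol-5-yl)-1-methylethyl in place of 3-carboxy-3-methylbutyl gives a number 4 percentage points lower from compound 2 to compound 3 (within the scatter), so the two chain ends cannot be told apart in this read-out, although one carries a five-membered aromatic ring with 4 hetero atoms and the other has no ring. The same tetrazole group in place of 2-cyano-2-methylpropyl gives a number 21 percentage points higher from compound 1 to compound 3 (beyond the scatter), which stands with a number 25 percentage points higher from compound 1 to compound 2 (beyond the scatter) and shows that, among these three compounds, the gain over the nitrile is not confined to the carboxylic acid. No available measurement explains why the tetrazole and acid compounds read alike or why both differ from the nitrile.

Since the tetrazole and the acid sit on chains of different length, the compounds shown leave the effects of chain end and chain length unseparated; a carboxylic acid on the chain of compound 3, or a tetrazole on the longer chain of compound 2, would separate them. Also open, from the compounds shown here alone, is how a primary amide or an amine at the chain end would read in this assay.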